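This account rests on a few compounds, and the source may have more. Where it says the series, first, only, none or still open, it means among the compounds named here.

Compound 1 `O=C(Nc1nc(-c2ccccn2)cs1)c1ccccc1O` and compound 2 `CC(=O)c1ccccc1C(=O)Nc1nc(-c2ccccn2)cs1` were both taken into an ADME assay on Vero cells (Chlorocebus sabaeus) for cytotoxicity, read by MTT assay, with a stated time of 72 h (on this read-out higher numbers stand for an effect only at larger amounts of compound and lower numbers for an effect already at smaller amounts), but only one of them yields a figure. In this assay compound 1 stands as "not determined" (no result reported) and adds nothing to any comparison. Within the data shown here, compound 2 gives 86700 nM in the same test, the only number available, so it can be ranked against no other compound. Compound 3 `O=C(Nc1nc(-c2ccccn2)cs1)c1ccccc1Br` has not yet been measured there. Its difference from compound 2 is bromo in place of acetyl on an aromatic carbon and amounts to bromo in place of acetyl on an aromatic carbon. Among the measured compounds shown here, no pair of measured compounds shows what such an exchange does in this assay, so the data offer no direct precedent. The expectation rests on compound 2 at 86700 nM as its only anchor, and no change beyond the scatter is expected, with a slight lean toward lower numbers. The expected size of the step is a 1.4-fold lower number from compound 2 to compound 3 (0.16 log units; within the scatter) in this estimate. For compound 3 the estimated value is 60000 nM with an expected range from 20000 nM to 160000 nM in this test.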

Compound 3, half-maximal effective concentration: 3500 nM
Beside the measured number, compound 3's estimate is 17-fold (1.23 log units) above it, outside the stated range (below it).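

In this assay, replacing acetyl with bromo gives a 25-fold lower number from compound 2 to compound 3 (1.39 log units; beyond the scatter), so this aromatic carbon, ortho to a large group, is a place where a single exchange on an otherwise unchanged molecule matters a great deal. Until now a lone figure could not show whether the group here had any bearing on the read-out, whereas this pair shows that the effect can appear at much smaller amounts of compound when bromo stands in place of acetyl. Nothing in the material at hand accounts for the size of this step, and it rests on this one pair alone.

Going by these compounds, what stays open is whether the step belongs to the arrival of bromo or to the departure of acetyl, since a single exchange changes both at once. Chloro, methyl, methoxy, an amine or a carboxylic acid on the same aromatic carbon would help separate these two readings, and would show whether the numbers follow a wider trend across groups at this place or whether bromo stands alone.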